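Swapping methoxy for chloro on a growth inhibitor

This account rests on a few compounds, and the source may have more. Where it says the series, first, only, none or still open, it means among the compounds named here.

In a functional assay on DU-145 cells (Homo sapiens) for inhibition, read by trypan blue exclusion, with a stated time of 96 h (a lower number here means a stronger inhibitor of growth, a higher number a weaker inhibitor of growth), compound 1 `O=C(/C(=C\c1ccc(Br)cc1)SCc1ccc(Cl)cc1)c1ccc(Br)cc1` gives 1000 nM and compound 2 `COc1ccc(/C=C(/SCc2ccc(Cl)cc2)C(=O)c2ccc(Br)cc2)cc1` gives 10000 nM, the higher of the two numbers. Compound 3 `O=C(/C(=C\c1ccc(Cl)cc1)SCc1ccc(Cl)cc1)c1ccc(Br)cc1` differs from compound 2 by chloro in place of methoxy on an aromatic carbon, para to a large group (chloro in place of methoxy on an aromatic carbon). Among the measured compounds shown here, only one measured step bears on this: a 10-fold higher number from compound 1 to compound 2 (1.00 log units; beyond the scatter), where methoxy took the place of bromo at that same carbon. Chloro removes that methoxy again, so a sizeable move towards a lower number is expected, though one step is thin evidence. The expected change is a 6.7-fold lower number from compound 2 to compound 3 (0.82 log units; beyond the scatter). For compound 3 the estimate is 1500 nM, with an expected range of 500 nM to 5000 nM.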

Compound 3, concentration for 50% growth inhibition: 10000 nM
Beside the measured number, compound 3's estimate is 6.7-fold (0.82 log units) below it; the measured number lies above the stated range.
By their numbers in this assay, from the lowest: compound 1; then compounds 2 and 3 (each within the scatter of the next).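

Swapping methoxy for chloro at this carbon brings no gain: there is no change at the digits printed from compound 2 to compound 3 (within the scatter). Chloro also falls short of bromo at the same place, with a 10-fold higher number from compound 1 to compound 3 (1.00 log units; beyond the scatter), so the lower number of compound 1 is tied to bromo here, not simply to the absence of methoxy. No measurement at hand explains this difference between bromo and chloro.

As far as these compounds go, whether iodo or an amine at this carbon would match bromo stays open. So does whether the bromo on the other aromatic ring of the shared core matters in the same way.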